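Series notes: chlorophenyl for methoxyphenyl on the shared core

This account rests on a few compounds, and the source may have more. Where it says the series, first, only, none or still open, it means among the compounds named here.

Compound 1 `COc1cccc(/C=C/C(=O)c2c(OC)cc(OC)cc2OC)c1` is the starting point of the series. Among the compounds with values here, in a functional assay on PC-3 cells (Homo sapiens), read by fluorescence and BrdU incorporation, with a stated time of 48 h, tested at 25 uM (on this read-out higher numbers stand for a weaker effect at the one concentration tested and lower numbers for a stronger effect), compound 1 gives 0.9%, the lowest of the two numbers so far; the nearest is compound 2 `COc1cc(O)c(C(=O)/C=C/c2ccccc2OC)c(OC)c1`, which in this assay gives 24%, a gap that lies beyond the scatter. Compound 3 `COc1cc(OC)c(C(=O)/C=C/c2ccc(Cl)cc2)c(OC)c1` has not yet been measured. It differs from compound 1 in one place: 4-chlorophenyl in place of 3-methoxyphenyl on a double-bonded chain carbon bound to a double-bonded chain carbon. Within the data shown here, no step between measured compounds covers this kind of change, so no size can be read off from the data. Given that compound 1 gives 0.9% in this assay, compound 3 is expected to stay strong, with the estimated step from compound 1 to compound 3 being a number 7.1 percentage points higher from compound 1 to compound 3 (within the scatter), a small weakening within or just beyond the scatter. Compound 3 is therefore estimated at 8% in this assay, with a range from 0.5% to 35%.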

Compound 3, a percentage reported as activity, at one concentration (the size of the read-out at that concentration, not a potency): 0.2%
Compound 3: the middle estimate sits 7.8 percentage points above what was measured, outside the stated range (below it).
By their numbers in this assay, from the lowest: compounds 3 and 1 (each within the scatter of the next); then compound 2.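

Within the data shown here, at this position, on a double-bonded chain carbon bound to a double-bonded chain carbon, the change to 4-chlorophenyl in place of 3-methoxyphenyl gives the first single-place step in this assay, and it reads a number 0.7 percentage points lower from compound 1 to compound 3 (within the scatter). The position therefore accepts an aryl group with chlorine and no hydrogen-bond acceptor as well as one with methoxy and a single acceptor, and the read-out stays within the scatter. Nothing on hand gives a reason for this result.

This swap alters the group's substituent and its ring placement together, so 4-methoxyphenyl and 3-chlorophenyl would be needed to read each separately. Going by these compounds, whether the tolerance extends to quite different groups here, such as an aminophenyl or a carboxyphenyl, stays open.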